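Working notes: from chloro to methyl in compound 4

The source may report more compounds than this note shows. Statements on the series, on what has been measured and on what is new or still open speak of the compounds shown alone.

Measured in an ADME assay on MDCK cells (Canis lupus familiaris) for cytotoxicity, read by MTT assay, with a stated time of 24 h; on this read-out higher numbers stand for lower toxicity in this test and lower numbers for higher toxicity in this test:
- compound 1 `N#Cc1ccc(S(=O)(=O)NCc2csc3ccccc23)cc1`: 122000 nM
- compound 2 `O=S(=O)(NCc1csc2ccccc12)c1cccc(F)c1`: "not determined" (no result reported)
- compound 3 `O=S(=O)(NCc1cc2ccccc2s1)c1ccc(Cl)cc1`: "not determined" (no result reported)

Among the compounds with values here, only one number is available so far. Compound 3 has no number of its own in this assay, so its standing cannot be placed against compound 1, and compound 2 offers no further reference. Within the data shown here, no measured pair differs in one place either, so the data show no step size.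

The next compound is compound 4 `Cc1ccc(S(=O)(=O)NCc2cc3ccccc3s2)cc1`. The structural change is methyl in place of chloro on an aromatic carbon, para to a large group, or 4-chlorophenyl to 4-methylphenyl.

Among the measured compounds shown here, with no measured step to draw on, no shift beyond the usual scatter is expected in this assay, and no direction can be favoured. For the measured compounds named here, the only anchor is compound 1 at 122000 nM, whose core is not the same as that of compound 4, so the range is kept wide.

Compound 4 is expected to read about 100000 nM, with an estimated range of 30000 nM to 300000 nM.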

Compound 4, half-maximal cytotoxic concentration: > 210000 nM
Compound 4: only a limit was reported (the forecaster's own chance of this, stated with the estimate: 30%); middle value at least 2.1-fold (0.32 log units) from the limit.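

No step can be read from compound 3 to compound 4 in this assay. Compound 4 gives > 210000 nM, which is a limit and not a number. The compounds shown leave open whether 4-chlorophenyl to 4-methylphenyl changes this read-out at all, and in which direction.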